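Amide to Urea on a Shared Sulfonate Core

A few compounds are considered here, and "the series" means these few. Any claim that something is new, unique, unknown or untested is made for them only; others in the source may bear on it.

Compound 1 `CC(=O)Nc1ccc(S(=O)(=O)Oc2ccccc2I)cc1`: 23000 nM
Compound 2 `CC(C)C(=O)Nc1ccc(S(=O)(=O)Oc2ccccc2I)cc1`: 13000 nM
Compound 3 `O=C(CCCCl)Nc1ccc(S(=O)(=O)Oc2ccccc2I)cc1`: 9100 nM

In a functional assay on HT-29 cells (Homo sapiens) for antiproliferative activity, read by sulforhodamine B assay, with a stated time of 48 h (on this read-out lower numbers stand for stronger inhibition and higher numbers for weaker inhibition), compound 3 carries the lowest of the three numbers. The step of a 2.5-fold lower number from compound 1 to compound 3 (0.40 log units; beyond the scatter) is modest but real, whereas a 1.4-fold lower number from compound 2 to compound 3 (0.15 log units; within the scatter) and a 1.8-fold lower number from compound 1 to compound 2 (0.25 log units; within the scatter) both stay within the scatter. Compound 4 `O=C(NCCCCl)Nc1ccc(S(=O)(=O)Oc2ccccc2I)cc1` is the next candidate; the change is (3-chloropropyl)amino in place of 3-chloropropyl on a carbonyl carbon. Among the measured compounds shown here, none of the measured steps tests a change of this kind: all three only swap the chain on the carbonyl carbon, and those swaps shifted this assay little. The step of a 1.1-fold higher number from compound 3 to compound 4 (0.04 log units; within the scatter) is therefore expected to be small, with no confident direction. Compound 4 is estimated at 10000 nM, within a range of 4000 nM to 25000 nM.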

Compound 4, half-maximal inhibitory concentration: 9600 nM
For compound 4 the middle estimate is 1.0-fold (0.02 log units) above the measured one, within the range that was stated.
By their numbers in this assay, from the lowest: compounds 3, 4, 2 and 1 (each within the scatter of the next, the first and the last beyond it).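

Replacing 3-chloropropyl with (3-chloropropyl)amino on the carbonyl carbon turns the amide into a urea and adds a hydrogen-bond donor, yet this assay shows no readable change (a 1.1-fold higher number from compound 3 to compound 4 (0.02 log units; within the scatter)). Compound 4 also stays within the scatter of the isopropyl amide (a 1.4-fold lower number from compound 2 to compound 4 (0.13 log units; within the scatter)), while it differs modestly from the methyl amide (a 2.4-fold lower number from compound 1 to compound 4 (0.38 log units; beyond the scatter)). No supporting evidence explains this result.

Still open, from the compounds shown here alone, is whether an amine in place of the chlorine, or a longer chain on the urea nitrogen, would shift the number.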